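Acetyl Capping and Its Effect on Cell Toxicity

This account rests on a few compounds, and the source may have more. Where it says the series, first, only, none or still open, it means among the compounds named here.

Three compounds sharing a common amide core were examined in an ADME assay on HEK-293T cells (Homo sapiens) for cytotoxicity, read by MTT assay, tested at 100 uM; on this read-out higher numbers stand for a weaker effect at the one concentration tested and lower numbers for a stronger effect. Compound 1 `O=C(Nc1ncc([N+](=O)[O-])s1)c1cc(Cl)ccc1O` gives 63% in this assay. Compound 2 `CC(=O)Oc1ccc(Cl)cc1C(=O)Nc1ncc([N+](=O)[O-])s1` differs from compound 1 in one place, (acetyl in place of hydrogen on an oxygen on an aromatic ring), and in this assay compound 2 gives 31.2%. That single change produced a number 31.8 percentage points lower from compound 1 to compound 2 (beyond the scatter). Compound 3 `CC(C)c1cc(C(=O)Nc2ncc([N+](=O)[O-])s2)c(O)c(C(C)C)c1` carries a different core, and the difference between the two cores is not broken down here. In this assay compound 3 gives 7.1%, the lowest of the three numbers, beyond the scatter from both compound 1 and compound 2.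

Compound 4 `CC(=O)Oc1c(C(=O)Nc2ncc([N+](=O)[O-])s2)cc(C(C)C)cc1C(C)C` is compound 3 with the same change applied, (acetyl in place of hydrogen on an oxygen on an aromatic ring). The place of the change is described in the same words for both pairs, so it is the same change, turning hydroxy into acetoxy. It has been measured only once, and that single example lowered the read-out strongly. Compound 3, however, already sits near the bottom of a percentage scale, which leaves little room for a drop of the same size. For compound 4 the estimated step is a number 4.1 percentage points lower from compound 3 to compound 4 (within the scatter), which rests on a number 31.8 percentage points lower from compound 1 to compound 2 (beyond the scatter) and on the low starting point of compound 3. Compound 4 is therefore expected to give 3%, with a likely range from 0% to 14%.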

Compound 4, a percentage reported as activity, at one concentration (the size of the read-out at that concentration, not a potency): 20.6%
For compound 4 the middle estimate is 17.6 percentage points below the measured one; measured number outside the range, above it.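

In this assay, replacing hydroxy with acetoxy on this second core gives a number 13.5 percentage points higher from compound 3 to compound 4 (beyond the scatter), so here the acetoxy compound shows the weaker effect on the read-out, whereas on the core of compound 1 it showed the stronger one. Set side by side, the two results differ in direction as well as in size: the same change on two cores in this assay, a number 31.8 percentage points lower (beyond the scatter) from compound 1 to compound 2 and a number 13.5 percentage points higher (beyond the scatter) from compound 3 to compound 4, 45.3 percentage points apart, beyond the scatter of two such steps. This shows that the step measured on one core cannot simply be carried over to another in this series, but two pairs do not show what sets the steps apart, nor which direction a third core would follow.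

The compounds shown leave open whether a longer chain in place of the acetyl, such as butanoyl on the same oxygen, would follow the step to compound 2 or the step to compound 4. They also leave open how the change would behave on a core carrying a different group, such as an amine or a carboxylic acid, in place of the chlorine of compound 1 or the isopropyl groups of compound 3.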